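Inverting One Stereocentre: Compound 3 to Compound 4

The source may hold more compounds than are shown below. What is called first, only, known or untested is meant among the compounds shown, and "the series" means these compounds.

- compound 1 `CC1=C(CC(=O)NCCN(C)C)c2cc(F)ccc2/C1=C\c1ccncc1`: 28900 nM
- compound 2 `CC1=C(CC(=O)NCCN(C)C)c2cc(F)ccc2/C1=C\c1ccc(S(C)(=O)=O)cc1`: > 50000 nM (a limit of the assay, not a number)
- compound 3 `COC(=O)[C@@H](C)NC(=O)CC1=C(C)/C(=C/c2ccc(SC)cc2)c2ccc(F)cc21`: 44200 nM

In a functional assay on PC-3 cells (Homo sapiens) for inhibition, read by CellTiter-Glo, with a stated time of 72 h (a higher number here means that more compound is tolerated, a lower number that less compound is tolerated), compound 3 gives 44200 nM, which lies within the scatter of compound 1 at 28900 nM. The value of compound 2 is a limit, so it cannot be placed exactly.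

Compound 4 `COC(=O)[C@H](C)NC(=O)CC1=C(C)/C(=C/c2ccc(SC)cc2)c2ccc(F)cc21` is compared here with compound 3: the two compounds have the same atoms and bonds and differ only in configuration as drawn: 1 of 2 stereo elements differ; a stereocentre at a saturated chain carbon is drawn R in compound 3 and S in compound 4. A stereocentre is an atom whose groups can be arranged in two mirror-image ways, so only the drawn arrangement changes at this one carbon.

Within the data shown here, the only measured step is an at least 1.7-fold higher number from compound 1 to compound 2 (0.23 log units; that floor lies within the scatter). Among the measured compounds shown here, it swaps a group elsewhere in the molecule, and no measured pair tests a change of configuration. The data therefore give no reason to expect a step beyond the scatter in this assay, in either direction.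

The estimated step is a 1.1-fold lower number from compound 3 to compound 4 (0.02 log units; within the scatter).

Compound 4 is expected at 42000 nM, with an estimated range from 20000 nM to 50000 nM.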

Compound 4, half-maximal cytotoxic concentration: > 50000 nM
Compound 4 gave a limit, no number; the forecaster's own chance of this, stated with the estimate: 30%; middle value at least 1.1-fold (0.07 log units) away from the limit.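

This pair is the first among the compounds shown to test a change of configuration alone, and in this assay it gives an at least 1.1-fold higher number from compound 3 to compound 4 (0.05 log units; that floor lies within the scatter). Any difference here can only come from the one inverted carbon, because nothing else separates the pair: the fact that compounds 3 and 4 differ only in the configuration as drawn. As far as these compounds go, compound 4 gives a limit, not a number, so only the floor of the step can be read and its true size stays unknown: the limit of > 50000 nM in this assay, at which 2 of the 4 values shown sit.

The compounds shown therefore leave open whether configuration at this carbon matters at all in this assay. Also open, from the compounds shown here alone, is whether a carboxylic acid in place of the ester, or a longer chain in place of the methyl on this carbon, would give the same picture in both configurations.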